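Amidine–thiophene series: methoxy to fluoro on the outer ring

The source may report more compounds than this note shows. Statements on the series, on what has been measured and on what is new or still open speak of the compounds shown alone.

Measured compounds:
compound 1, `COc1ccc(-c2ccc(-c3ccc(C(=N)N)cc3)s2)cc1`, 1730 nM
compound 2, `N=C(N)c1ccc(-c2ccc(-c3cc(Cl)cc(Cl)c3)s2)cc1`, 1700 nM

Of the compounds shown here, two of the shared core have been measured in a functional assay on OVCAR-3 cells (Homo sapiens) for inhibition, read by sulforhodamine B assay, with a stated time of 48 h; on this read-out higher numbers stand for weaker inhibition of growth and lower numbers for stronger inhibition of growth. Compound 1 gives 1730 nM, the higher of the two numbers, while compound 2 gives 1700 nM; the gap between them lies within the usual scatter, so the two cannot be told apart on this read-out. Compound 3, `N=C(N)c1ccc(-c2ccc(-c3ccc(F)cc3)s2)cc1`, has not been measured. It differs from compound 1 in one place: fluoro in place of methoxy on an aromatic carbon. Going by the values given here, no pair of measured compounds differing in a single place is available, so the size of such a step cannot be read from the data. With the two measured values sitting together, no step beyond the scatter is expected from compound 1 to compound 3. Compound 3 is estimated at 2000 nM, with a range of 700 nM to 6000 nM. The step this estimate means is a 1.2-fold higher number from compound 1 to compound 3 (0.06 log units; within the scatter), expected to stay within the scatter.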

Compound 3, concentration for 50% growth inhibition: 1710 nM
Compound 3: the middle estimate sits 1.2-fold (0.07 log units) above what was measured, and the stated range covers the measured number.
By their numbers in this assay, from the lowest: compounds 2, 3 and 1 (each within the scatter of the next).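

In this assay, fluoro in place of methoxy on an aromatic carbon, para to a large group, gives a 1.0-fold lower number from compound 1 to compound 3 (0.01 log units; within the scatter), the first single-place step available in the series. Going by these compounds alone, at this position, then, exchanging methoxy for fluoro, which leaves one hydrogen-bond acceptor and one heavy atom fewer, produces no step that can be told from the scatter. Nothing on hand bears on why these two groups read alike.

A single pair cannot show whether this position is indifferent to its substituent in general, and an amine, a carboxylic acid or a longer chain such as butoxy could still shift the number. Going by these compounds, it also remains open whether the same exchange would stay within the scatter on a core carrying a different group at the amidine end.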